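The source may hold more compounds than are shown below. What is called first, only, known or untested is meant among the compounds shown, and "the series" means these compounds.

Measured compounds:
- compound 1 `O=C(OCc1ccc(Cl)c(Cl)c1)N(c1ccccc1)C1CN2CCC1CC2`, in an assay on CHO cells for displacement of a labelled ligand from muscarinic acetylcholine receptor M5 (Homo sapiens), read by scintillation counting, with a stated time of 2 h (a lower number here means a stronger inhibitor, a higher number a weaker inhibitor), compound 1 gives 60 nM
- compound 2 `Cc1ccc(COC(=O)N(c2ccccc2)C2CN3CCC2CC3)cc1F`, compound 2 gives 30 nM
- compound 3 `COc1ccc(CCCOC(=O)N(c2ccccc2)C2CN3CCC2CC3)cc1F`, compound 3 gives 260 nM

All three share the same core, a carbamate carrying a phenyl group on its nitrogen and a bicyclic amine; they differ only in the group hanging from the ester oxygen. Compound 1 sits second highest of the three numbers in this assay. Its nearest neighbour is compound 2, reached by a 2.0-fold lower number from compound 1 to compound 2 (0.30 log units; within the scatter); the furthest is compound 3, whose value is clearly higher than that of compound 1.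

Compound 4 `O=C(OCCc1ccccc1)N(c1ccccc1)C1CN2CCC1CC2` has not been measured. Relative to compound 1 the change is benzyl in place of 3,4-dichlorophenyl on a saturated chain carbon bound to an oxygen next to a carbonyl group. For the measured compounds named here, only one measured step touches the same position, and it was small: the swap to compound 2 stayed within the scatter, showing that exchanging the two substituents on that aromatic ring for others changed little. Going by the values given here, compound 3, with a longer chain and a differently substituted ring, gives a distinctly higher number, but there is no single-point step linking it to compound 1, so it only hints that lengthening the chain may cost potency. On balance a modest rise is expected, estimated as a 2.0-fold higher number from compound 1 to compound 4 (0.30 log units; within the scatter).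

Compound 4 is therefore expected to give about 120 nM in this assay, within a range of 40 nM to 400 nM.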

Compound 4, inhibition constant: 260 nM
Compound 4: the middle estimate sits 2.2-fold (0.34 log units) below what was measured; the range from low to high includes it.
By their numbers in this assay, from the lowest: compounds 2 and 1 (each within the scatter of the next); then compounds 3 and 4 (each within the scatter of the next).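

In this assay the swap of 3,4-dichlorobenzyl for phenethyl gives a 4.3-fold higher number from compound 1 to compound 4 (0.64 log units; beyond the scatter) and so, unlike the earlier step at this position, moves the number beyond the scatter. The same exchange made on the other close relative gives an 8.7-fold higher number from compound 2 to compound 4 (0.94 log units; beyond the scatter) and confirms that this position does respond to the group placed on it: compound 1 and compound 2, each with a benzyl group bearing two ring substituents, both sit clearly lower than phenethyl compound 4. Exchanging 3-fluoro-4-methoxybenzyl for phenyl, two bonds along the chain from the oxygen, gives no change at the digits printed from compound 3 to compound 4 (within the scatter) and so, in that pair, this outer part of the group can be altered with no visible effect on the number.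

The step from compound 1 to compound 4 alters the ring substituents and the chain together, so a 3,4-dichlorophenethyl group or an unsubstituted benzyl group would be needed to separate the two, and an amine on the ring remains untested among these compounds. No accompanying measurement offers an explanation for any of these differences.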